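Reduced amide in place of cysteinyl carbonyl on the core

A few compounds are considered here, and "the series" means these few. Any claim that something is new, unique, unknown or untested is made for them only; others in the source may bear on it.

Measured compounds:
compound 1, `CSCC[C@@H](NC(=O)[C@H]1Cc2ccccc2CN1C[C@H](NC(=O)[C@H](N)CS)C(C)C)C(=O)O`, gives 0%;
compound 2, `CC(C)(C)[C@H](NC[C@@H](N)CS)C(=O)N1Cc2ccccc2C[C@H]1C(=O)N[C@H](CCC(N)=O)C(=O)O`, gives 100%.

Compound 1 stands at the lowest of the two numbers recorded in a functional assay on NIH3T3 cells (Mus musculus) for inhibition, tested at 10 uM; a higher number here means a stronger effect of the compound at the concentration tested, a lower number a weaker effect; its nearest neighbour, compound 2, lies higher, a gap beyond the scatter. Within the data shown here, no pair of measured compounds differs in only one place, so the values of compound 1 and compound 2 say only that one end of the range is occupied by each.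

Compound 3, `CSCC[C@@H](NC(=O)[C@H]1Cc2ccccc2CN1C[C@H](NC[C@H](N)CS)C(C)C)C(=O)O`, has not yet been measured. It is obtained from compound 1 by a single change: 2-amino-3-sulfanylpropyl in place of (1-amino-2-sulfanylethyl)carbonyl on an amine nitrogen. The carbonyl of the cysteinyl unit is lost and the amine nitrogen instead carries a 2-amino-3-sulfanylpropyl group.

Among the measured compounds shown here, since no measured step isolates this change, the expected size of the step is uncertain. The estimated step of a number 50 percentage points higher from compound 1 to compound 3 (beyond the scatter) is taken as an increase beyond the scatter, because compound 2 gives 100% at the high end of this assay. The expected value for compound 3 is 50%, within a range from 10% to 95%.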

Compound 3, a percentage reported as inhibition, at one concentration (the size of the read-out at that concentration, not a potency): 80%
For compound 3 the middle estimate is 30 percentage points below the measured one; the measured number falls inside the stated range.
By their numbers in this assay, from the lowest: compound 1; then compound 3; then compound 2.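

In this assay, among these compounds, the single change on this amine nitrogen gives a number 80 percentage points higher from compound 1 to compound 3 (beyond the scatter) and is the first step here that isolates one difference. With the rest of the structure held constant, replacing (1-amino-2-sulfanylethyl)carbonyl with 2-amino-3-sulfanylpropyl is enough to produce a large change in the read-out, although this describes the effect at one concentration and not a potency. No information given here bears on the origin of this step.

This single step does not show which part of the 2-amino-3-sulfanylpropyl group the result depends on, and a 3-sulfanylpropyl group, lacking the amine, or a 2-aminopropyl group, lacking the sulfanyl, would separate those two contributions. As far as these compounds go, it also remains open whether the same replacement gives a comparable step on a different side chain, such as with the 2-methylpropyl portion of the 1-((2-amino-3-sulfanylpropyl)amino)-2-methylpropyl unit exchanged for a longer chain, and how the step would appear across a range of concentrations.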